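Carbamoyl to hydroxymethyl: an estimate for compound 3

The source may report more compounds than this note shows. Statements on the series, on what has been measured and on what is new or still open speak of the compounds shown alone.

Compound 1 `COc1cc(C(=O)N2[C@@H](c3nccs3)[C@@H](C(N)=O)C[C@@]2(CC(C)C)C(=O)O)ccc1C(C)(C)C`: 37 mL/min/kg
Compound 2 `CC(C)C[C@@]1(C(=O)O)C[C@H](C(N)=O)[C@H](c2nccs2)N1C(=O)c1ccc(C(C)(C)C)cc1`: 21 mL/min/kg

Only these two compounds have been measured in an in vivo ADME assay on the whole organism (plasma, strain Sprague-Dawley) for pharmacokinetics, with Rattus norvegicus as the target, at a dose of 1 mg/kg by the intravenous route; on this read-out lower numbers stand for slow clearance and higher numbers for fast clearance. Compound 1 has the highest of the two numbers, but the gap lies within the usual scatter of repeated measurements, so the two cannot really be told apart. That single measured step, a 1.8-fold lower number from compound 1 to compound 2 (0.25 log units; within the scatter), is hydrogen in place of methoxy on an aromatic carbon.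

Compound 3 `COc1cc(C(=O)N2[C@@H](c3nccs3)[C@@H](CO)C[C@@]2(CC(C)C)C(=O)O)ccc1C(C)(C)C` differs from compound 1 in another way: hydroxymethyl in place of carbamoyl on a saturated ring carbon. For the measured compounds named here, no measured step covers this change, so the data cannot size it directly. The best starting point is compound 1 itself at 37 mL/min/kg, and no shift beyond the scatter is expected. The expected step is a 1.1-fold lower number from compound 1 to compound 3 (0.02 log units; within the scatter). Compound 3 is estimated at 35 mL/min/kg, with an expected range from 15 mL/min/kg to 75 mL/min/kg.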

Compound 3, clearance: 36 mL/min/kg
Compound 3: middle estimate off by 1.0-fold (0.01 log units), on the low side, and the stated range covers the measured number.
By their numbers in this assay, from the lowest: compounds 2, 3 and 1 (each within the scatter of the next).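

Replacing carbamoyl with hydroxymethyl on this saturated ring carbon gives, in this assay, a 1.0-fold lower number from compound 1 to compound 3 (0.01 log units; within the scatter), so the two compounds cannot be told apart. For the compounds shown here, this is the first measured change at this position, as the earlier pair differed only on an aromatic carbon. On the core of compound 1, then, this ring carbon can carry either group with no clearance difference beyond the scatter, and nothing available here bears on why.

One pair cannot show whether the same swap would behave alike on the core of compound 2, which has hydrogen in place of methoxy. It also leaves open how clearance would respond to a different group on this ring carbon, such as an amine, a carboxylic acid or a longer chain.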